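Replacing pentan-3-yl on the oxygen: expected clearance

The source may report more compounds than this note shows. Statements on the series, on what has been measured and on what is new or still open speak of the compounds shown alone.

In an ADME assay on microsomes from liver (Rattus norvegicus) for metabolic stability (a higher number here means faster removal of the compound, a lower number slower removal), compound 3 `CCC(CC)Oc1cc(Oc2cnc(C(=O)N(C)C)nc2)cc(-c2nccc(=O)[nH]2)c1` gives 91 mL/min/kg and stands within the scatter of both other measured compounds. In this assay compound 1 `Cc1ccc(NC(=O)c2cc(Oc3ccc(S(C)(=O)=O)cc3)cc(OC(C)C)c2)nc1` gives 97 mL/min/kg and compound 2 `Cc1cc(=O)[nH]c(-c2cc(Oc3ccc(S(C)(=O)=O)cc3)cc(OC(C)C)c2)n1` gives 96 mL/min/kg so the three numbers cannot be ranked.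

Compound 4 `COC[C@H](C)Oc1cc(Oc2cnc(C(=O)N(C)C)nc2)cc(-c2nccc(=O)[nH]2)c1` departs from compound 3 at one place. The difference is 1-(methoxymethyl)ethyl in place of pentan-3-yl on an oxygen on an aromatic ring and the entering group also brings a defined stereocentre.

For the measured compounds named here, the only measured step (a 1.0-fold lower number from compound 1 to compound 2 (0.00 log units; within the scatter)) exchanges a group on an aromatic carbon, not on this oxygen, and it stays within the scatter. No measured pair isolates a change of the group on this oxygen, so the size of this step is not directly shown. Compound 3 also differs from compound 1 and compound 2 in more than one place, yet all three values stay within the scatter of each other. That gives no ground for expecting a large step, and the downward lean here is a judgement on the new group alone. In this assay the estimated step is a 1.3-fold lower number from compound 3 to compound 4 (0.11 log units; within the scatter) and nothing firmly beyond the scatter is expected. For compound 4 70 mL/min/kg is estimated, with 35 mL/min/kg to 100 mL/min/kg as the expected range.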

Compound 4, clearance: 38 mL/min/kg
The estimate for compound 4 lay 1.8-fold (0.27 log units) above the measured number; the measured number falls inside the stated range.
By their numbers in this assay, from the lowest: compound 4; then compounds 3, 2 and 1 (each within the scatter of the next).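

In this assay, for the compounds shown here, the group on the oxygen on an aromatic ring is the first single place in this set where a change moves the number beyond the scatter, with 1-(methoxymethyl)ethyl in place of pentan-3-yl giving a 2.4-fold lower number from compound 3 to compound 4 (0.38 log units; beyond the scatter) in a step printed as modest. Both groups hold the same count of heavy atoms, so the step does not come with a difference in that count; it comes instead with an oxygen in the chain, a hydrogen-bond acceptor and a defined stereocentre, and the data do not separate these three features. Nothing available bears on why the number moves.

The compounds shown leave open whether the step belongs to the chain oxygen or to the stereocentre, which the opposite stereoisomer of 1-(methoxymethyl)ethyl and an unbranched 2-methoxyethyl chain on the same oxygen would help to separate. They also leave open whether a different atom in the chain, such as an amine nitrogen, would give a similar step, and whether the same exchange would carry over to the cores of compound 1 and compound 2.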